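Propylsulfanyl for propoxy on a methylenecyclopropane purine

The compounds below may be only part of what the source reports. "The series", "measured", "known", "first", "only" and "open" are said of these compounds alone.

Compounds measured so far:
- compound 1, `CCCCCCCCOc1nc(N)nc2c1ncn2/C=C1/CC1(CO)CO`: > 20000 nM
- compound 2, `CC(C)CNc1nc(N)nc2c1ncn2/C=C1/CC1(CO)CO`: "not determined" (no result reported)
- compound 3, `CCCOc1nc(N)nc2c1ncn2/C=C1/CC1(CO)CO`: > 20000 nM

Three compounds share a core. In an ADME assay on MOLT-3 cells (Homo sapiens) for cytotoxicity, with a stated time of 7 days (a higher number here means that more compound is tolerated, a lower number that less compound is tolerated), compound 1 reaches only the limit of the assay, at > 20000 nM. Compound 2 has no result in this assay; its value is given as "not determined" (no result reported). Compound 3 likewise stops at the limit, at > 20000 nM. Compound 3 therefore stands where compound 1 stands, at the limit of the assay, with compound 2 giving no number at all. Among the compounds with values here, the one change between measured compounds, a step that the two limits leave unreadable from compound 1 to compound 3, cannot be read, since both of its ends sit at the limit, as the limit of > 20000 nM in this assay, at which 2 of the 3 values shown sit, notes.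

Compound 4, `CCCSc1nc(N)nc2c1ncn2/C=C1/CC1(CO)CO`, differs from compound 3 by propylsulfanyl in place of propoxy on an aromatic carbon.

Within the data shown here, no measured step bears directly on this exchange, and the only computed step is unreadable. Both readable neighbours sit at the limit, so for compound 4 the expected outcome in this assay is again a limit rather than a number: the step from compound 3 is estimated as a step that the limit leaves unreadable from compound 3 to compound 4. Compound 4 is therefore expected to tolerate roughly 40000 nM, between 15000 nM and 150000 nM.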

Compound 4, half-maximal cytotoxic concentration: > 20000 nM
Compound 4: a limit, no number; the forecaster's own chance of this, stated with the estimate: 80%; the middle value is on the limit's open side.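

In this assay compound 4 gives > 20000 nM as a limit, not a number. No new step can be read, neither from compound 3 nor from compound 1 to compound 4, because both ends of each sit at a limit: the limit of > 20000 nM in this assay, at which 3 of the 4 values shown sit.

The compounds shown leave open how compound 1, compound 3 and compound 4 would compare beyond that limit.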